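A few compounds are considered here, and "the series" means these few. Any claim that something is new, unique, unknown or untested is made for them only; others in the source may bear on it.

Measured in an assay on BaF3 cells for displacement of a labelled ligand from C-X-C chemokine receptor type 1 (Homo sapiens); a higher number here means a weaker inhibitor, a lower number a stronger inhibitor:
Compound 1 `CC[C@@H](Nc1c(Nc2cccc(C(=O)N(C)C)c2O)c(=O)c1=O)c1ccc(C)s1`: 235 nM
Compound 2 `Cc1ccc([C@@H](C)Nc2c(Nc3cccc(C(=O)N(C)C)c3O)c(=O)c2=O)o1`: 775 nM

Compound 2 gives the highest number of the two, and its gap to the nearest measured compound is a 3.3-fold higher number from compound 1 to compound 2 (0.52 log units; beyond the scatter), beyond the scatter. Compound 3 `Cc1ccc([C@H](Nc2c(Nc3cccc(C(=O)N(C)C)c3O)c(=O)c2=O)C2CC2)o1` differs from compound 2 by cyclopropyl in place of methyl on a saturated chain carbon bound to an aromatic carbon and a nitrogen on an aromatic ring. For the measured compounds named here, the only measured step that touches this carbon is the one from compound 1 to compound 2, which replaced 1-(5-methylthiophen-2-yl)propyl with 1-(5-methylfuran-2-yl)ethyl, changing the ring together with the chain, so it bears on the present change only loosely; it does show that the larger group at this carbon went with the lower number. On that basis a modest step to a lower number is expected for compound 3, a 2.6-fold lower number from compound 2 to compound 3 (0.41 log units; beyond the scatter). Compound 3 is therefore estimated at 300 nM, with a range of 100 nM to 900 nM.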

Compound 3, half-maximal inhibitory concentration: 55 nM
For compound 3 the middle estimate is 5.5-fold (0.74 log units) above the measured one; the whole stated range lies above it.
By their numbers in this assay, from the lowest: compound 3; then compound 1; then compound 2.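

In this assay, for the compounds shown here, with the 5-methylfuran-2-yl part held constant, cyclopropyl in place of methyl on the saturated chain carbon gives a 14-fold lower number from compound 2 to compound 3 (1.15 log units; beyond the scatter), the first reading of this carbon on its own; the earlier pair changed ring and chain together. The full group change gives a 4.3-fold lower number from compound 1 to compound 3 (0.63 log units; beyond the scatter), so a group carrying the furan can give a lower number than 1-(5-methylthiophen-2-yl)propyl, and the higher number of compound 2 does not hold for furan groups in general. Nothing measured here explains the size of the step from methyl to cyclopropyl.

Still open, on these data alone, is whether an isopropyl or cyclobutyl group on this carbon would match cyclopropyl, or whether the three-membered ring itself matters. Also open, as far as these compounds go, is how the furan and thiophene rings compare with the same chain on this carbon.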